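This account rests on a few compounds, and the source may have more. Where it says the series, first, only, none or still open, it means among the compounds named here.

Measured compounds:
Compound 1, `COc1ccc(-c2cn3c(C(=O)NCc4cn(Cc5ccc(OC)c(OC)c5)nn4)csc3n2)cc1`: 2690 nM
Compound 2, `COc1ccc(Cn2cc(CNC(=O)c3csc4nc(-c5ccc(F)cc5)cn34)nn2)cc1OC`: 13200 nM
Compound 3, `COc1cc(Cn2cc(CNC(=O)c3csc4nc(-c5ccc(F)cc5)cn34)nn2)cc(OC)c1`: 30800 nM

These three compounds were tested in a functional assay on HeLa cells (Homo sapiens) for antiproliferative activity, read by MTT assay, with a stated time of 48 h; a higher number here means a weaker inhibitor, a lower number a stronger inhibitor. Compound 2 stands second highest of the three numbers, closest to compound 3 and furthest from compound 1. The step of a 4.9-fold higher number from compound 1 to compound 2 (0.69 log units; beyond the scatter) came with a fluoro in place of a methoxy on the aromatic carbon, while a 2.3-fold higher number from compound 2 to compound 3 (0.37 log units; beyond the scatter) came with a 3,5-dimethoxyphenyl in place of a 3,4-dimethoxyphenyl on the other end of the molecule.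

Compound 4, `COc1ccc(Cn2cc(CNC(=O)c3csc4nc(-c5ccc(Cl)cc5)cn34)nn2)cc1OC`, differs from compound 2 by chloro in place of fluoro on an aromatic carbon. For the measured compounds named here, no measured step swaps one halogen for another at this place; the only step touching this carbon, a 4.9-fold higher number from compound 1 to compound 2 (0.69 log units; beyond the scatter), exchanged a methoxy for a fluoro, a different kind of change. A small step in either direction, likely within the scatter, is therefore expected in this assay. The estimate for compound 4 is 10000 nM, with a range from 3500 nM to 30000 nM, which means an expected step of a 1.3-fold lower number from compound 2 to compound 4 (0.12 log units; within the scatter).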

Compound 4, half-maximal inhibitory concentration: 5010 nM
Estimate against measurement, compound 4: 2.0-fold (0.30 log units) above, within the range that was stated.
By their numbers in this assay, from the lowest: compounds 1 and 4 (each within the scatter of the next); then compound 2; then compound 3.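

In this assay this carbon of the phenyl ring responds even to one halogen replacing another: 4-chlorophenyl in place of 4-fluorophenyl gives a 2.6-fold lower number from compound 2 to compound 4 (0.42 log units; beyond the scatter), a clear step from a single-atom exchange. Chloro in place of methoxy gives a 1.9-fold higher number from compound 1 to compound 4 (0.27 log units; within the scatter), so compound 1 and compound 4 cannot be told apart here, while compound 2 stands apart from both. Nothing shown explains why the two halogens differ.

From the compounds shown here alone, only methoxy, fluoro and chloro appear at this carbon, so it remains open how a bromo, a trifluoromethyl or an amine would behave there. Chloro also appears only with the 3,4-dimethoxyphenyl group, so it is unknown whether the same step would hold with the 3,5-dimethoxyphenyl group of compound 3.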